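Ester chain lengthening: compound 3 to compound 4

The source may report more compounds than this note shows. Statements on the series, on what has been measured and on what is new or still open speak of the compounds shown alone.

In a functional assay on HCT-116 cells (Homo sapiens) for inhibition, read by MTT assay, with a stated time of 48 h (a higher number here means a weaker inhibitor, a lower number a stronger inhibitor), compound 1 (`COc1ccc(N(C)c2nc(C)nc3ccccc23)cc1C(=O)OCC[Se]C#N`) gives 951 nM, compound 2 (`COc1ccc(N(C)c2nc(C)nc3ccccc23)cc1C(=O)NCC[Se]C#N`) gives 313 nM and compound 3 (`COc1ccc(N(C)c2nc(C)nc3ccccc23)cc1C(=O)OCCCC[Se]C#N`) gives 662 nM. Two measured steps fix the standing of compound 3: a 1.4-fold lower number from compound 1 to compound 3 (0.16 log units; within the scatter), and a 2.1-fold higher number from compound 2 to compound 3 (0.33 log units; beyond the scatter). Its number therefore cannot be separated from that of the shorter ester, while the amide keeps a lower number.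

Compound 4 (`COc1ccc(N(C)c2nc(C)nc3ccccc23)cc1C(=O)OCCCCC[Se]C#N`) differs by a group of 4 heavy atoms (2 carbon, 1 nitrogen, 1 selenium; no ring) in place of a group of 3 heavy atoms (1 carbon, 1 nitrogen, 1 selenium; no ring), on a saturated chain carbon, four bonds along the chain from an oxygen next to a carbonyl group, which lengthens the same ester chain again. Within the data shown here, the closest precedent is the one earlier lengthening of this chain, a 1.4-fold lower number from compound 1 to compound 3 (0.16 log units; within the scatter). The ester-to-amide step, a 3.0-fold lower number from compound 1 to compound 2 (0.48 log units; beyond the scatter), is larger but concerns a different change and bears on this one only weakly. A single chain step is thin evidence, and no trend can be drawn from it. No step beyond the scatter is therefore expected in this assay, and no direction is favoured.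

The estimated outcome is a 1.1-fold lower number from compound 3 to compound 4 (0.03 log units; within the scatter). For compound 4 the estimated value is 620 nM, with an expected range of 300 nM to 1300 nM.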

Compound 4, half-maximal inhibitory concentration: 551 nM
Compound 4: middle estimate off by 1.1-fold (0.05 log units), on the high side, and the stated range covers the measured number.
By their numbers in this assay, from the lowest: compounds 2, 4, 3 and 1 (each within the scatter of the next, the first and the last beyond it).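

In this assay the further lengthening of the ester chain gives a 1.2-fold lower number from compound 3 to compound 4 (0.08 log units; within the scatter) and the whole lengthening gives a 1.7-fold lower number from compound 1 to compound 4 (0.24 log units; within the scatter), so the three esters shown form a flat stretch in which chain length at this position has no readable effect. The amide comparison also loosens: a 1.8-fold higher number from compound 2 to compound 4 (0.25 log units; within the scatter) is printed as within the scatter, so this ester cannot be separated from the amide, though the shortest ester, compound 1, can. No measured evidence here accounts for this insensitivity to chain length.

The compounds shown leave open whether a longer chain would stay as flat, and whether an amide on the longer chains would follow the esters. On these data alone, a carboxylic acid or an amine at the chain end also remains untested.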